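A Chlorine Added to an Aromatic Carbon

A few compounds are considered here, and "the series" means these few. Any claim that something is new, unique, unknown or untested is made for them only; others in the source may bear on it.

Compound 1, `Cc1cc(N2CC[C@@H]3CN[C@@H]3C2)cnc1Cl`: 71 nM in a functional assay on HEK293 cells for agonist activity at Neuronal acetylcholine receptor; alpha3/beta4 (Homo sapiens), read by FLIPR; on this read-out higher numbers stand for an effect only at larger amounts of compound and lower numbers for an effect already at smaller amounts
Compound 2, `Cc1cncc(N2CC[C@@H]3CN[C@@H]3C2)c1`: 1400 nM
Compound 3, `c1cncc(N2C[C@@H]3CCNC[C@@H]32)c1`: 1700 nM

Compound 1 and compound 2 share one core and differ in a single place: chloro in place of hydrogen on an aromatic carbon. This change brought a 20-fold lower number from compound 2 to compound 1 (1.29 log units; beyond the scatter). Compound 3 is built on a different core; the difference between the two cores is not broken down here. The number for compound 3 and the number for compound 2 lie within the usual scatter of each other.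

Compound 4, `Clc1ccc(N2C[C@@H]3CCNC[C@@H]32)cn1`, has not yet been measured. It stands to compound 3 as compound 1 stands to compound 2: chloro in place of hydrogen on an aromatic carbon. The two places are not the same word for word: in compound 1 the chloro is also ortho to a methyl group (1 heavy atom), which compound 4 does not have, so the two changes are the same kind of change, not the same. Because of a 20-fold lower number from compound 2 to compound 1 (1.29 log units; beyond the scatter) a lower number is also expected for compound 4, estimated as an 8.5-fold lower number from compound 3 to compound 4 (0.93 log units; beyond the scatter), somewhat smaller since the surroundings of the place differ. Compound 4 is expected to give about 200 nM, between 50 nM and 700 nM.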

Compound 4, half-maximal effective concentration: 1390 nM
The estimate for compound 4 lay 7.0-fold (0.84 log units) below the measured number; measured number above the stated range.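

In this assay, chloro in place of hydrogen on an aromatic carbon gave a 1.2-fold lower number from compound 3 to compound 4 (0.09 log units; within the scatter), so on this core the change had no effect that can be told apart from the scatter. The large step seen on the core of compound 1 therefore did not carry over to the core of compound 4, which shows that in this series the effect of this change cannot simply be transferred from one core to another: the same change on two cores in this assay, a 20-fold lower number (1.29 log units; beyond the scatter) from compound 2 to compound 1 and a 1.2-fold lower number (0.09 log units; within the scatter) from compound 3 to compound 4, 16-fold (1.21 log units) apart, beyond the scatter of two such steps What this does not show is why the two results differ, since the cores differ and compound 1 and compound 2 also carry a methyl group that compound 3 and compound 4 lack, and one pair per core cannot separate these two differences.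

From the compounds shown here alone, it remains open whether adding a methyl group to the aromatic ring of compound 4 would bring the large step back. Going by these compounds, it is also open whether fluoro, bromo or methoxy on the same aromatic carbon would behave as chloro does on either core.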